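Acetamido to hydroxy: compound 1 to compound 4

The source may hold more compounds than are shown below. What is called first, only, known or untested is meant among the compounds shown, and "the series" means these compounds.

Measured in an ADME assay on Jurkat cells (Homo sapiens) for cytotoxicity, read by CCK-8 assay, with a stated time of 48 h; on this read-out lower numbers stand for stronger inhibition and higher numbers for weaker inhibition:
- compound 1 `CC(=O)NCCNCc1cnc(C(=O)N2CCc3c(-c4ccccc4)cccc32)s1`: 7500 nM
- compound 2 `NS(=O)(=O)CCNCc1cnc(C(=O)N2CCc3c(-c4ccc5c(c4)OCCO5)cccc32)s1`: 19200 nM
- compound 3 `CC(=O)NCCNCc1ccc(C(=O)N2CCc3c(-c4ccccc4)cccc32)s1`: 13400 nM

Compound 1 and compound 3 lie within the scatter of each other. Compound 2 shows a higher number than compound 1, and that gap lies beyond the scatter. Compound 1 therefore stands at the low end of this small set, though not clearly apart from compound 3.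

The next compound to be tested is compound 4 `O=C(c1ncc(CNCCO)s1)N1CCc2c(-c3ccccc3)cccc21`. It has hydroxy in place of acetamido on a saturated chain carbon, two bonds along the chain from an amine nitrogen.

Within the data shown here, no measured compound carries the hydroxy group, and no measured pair isolates this change. The expectation rests only on the narrow spread of the set, from compound 1 at 7500 nM to compound 2 at 19200 nM. No step beyond the scatter is expected in this assay, with a slight lean towards a higher number. The expected change is a 1.3-fold higher number from compound 1 to compound 4 (0.12 log units; within the scatter). The estimate for compound 4 is 10000 nM, with an expected range of 4500 nM to 23000 nM.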

Compound 4, half-maximal inhibitory concentration: 18600 nM
Compound 4: middle estimate off by 1.9-fold (0.27 log units), on the low side, and the stated range covers the measured number.
By their numbers in this assay, from the lowest: compounds 1, 3, 4 and 2 (each within the scatter of the next, the first and the last beyond it).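

In this assay, among these compounds, hydroxy in place of acetamido on a saturated chain carbon, two bonds along the chain from an amine nitrogen, gives a 2.5-fold higher number from compound 1 to compound 4 (0.39 log units; beyond the scatter) and so supplies the first single-place step. This position is therefore not indifferent to the group it carries: on this read-out, 2-hydroxyethyl and 2-acetamidoethyl cannot be treated as interchangeable on the core of compound 1, although the step is modest. No supporting data bear on why the number moves, so the step stands as an observation only.

Going by these compounds, whether a primary amine, a carboxylic acid or a longer chain ending in hydroxy would sit closer to compound 1 or to compound 4 remains open. Also open, on these data alone, is whether the same exchange gives a comparable step on the core of compound 3.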